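A few compounds are considered here, and "the series" means these few. Any claim that something is new, unique, unknown or untested is made for them only; others in the source may bear on it.

In an ADME assay on CCRF-HSB-2 cells (Homo sapiens) for cytotoxicity, with a stated time of 7 days (a higher number here means that more compound is tolerated, a lower number that less compound is tolerated), compound 1 `CC(C)CSc1nc(N)nc2c1ncn2/C=C1/CC1(CO)CO` gives 60000 nM. Compound 2 `Nc1nc(OCc2ccccc2)c2ncn(/C=C3/CC3(CO)CO)c2n1` gives in this assay only a limit of the assay, > 20000 nM. Compound 3 `CC(C)CNc1nc(N)nc2c1ncn2/C=C1/CC1(CO)CO` likewise gives in this assay only a limit, > 20000 nM. The steps among the measured compounds, a step that the limit leaves unreadable from compound 1 to compound 2, a step that the limit leaves unreadable from compound 1 to compound 3 and a step that the two limits leave unreadable from compound 2 to compound 3, cannot be sized because of the limit of > 20000 nM in this assay, at which 2 of the 3 values shown sit. Compound 3 thus stands at the limit of this assay, with no number of its own to anchor a step.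

Compound 4 `CCCCNc1nc(N)nc2c1ncn2/C=C1/CC1(CO)CO` differs from compound 3 by propyl in place of isopropyl on a saturated chain carbon bound to a nitrogen on an aromatic ring. For the measured compounds named here, none of the measured steps bears on this change: each of them exchanges the whole group on the aromatic carbon, and all three are unreadable because of the limit of > 20000 nM in this assay, at which 2 of the 3 values shown sit. No step beyond the scatter is therefore expected for this change in this assay, and compound 4 is expected to sit at or near the limit as well. Compound 4 is estimated at 50000 nM, within 20000 nM to 150000 nM. That amounts to an expected step that the limit leaves unreadable from compound 3 to compound 4.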

Compound 4, half-maximal cytotoxic concentration: > 20000 nM
Compound 4: only a limit was reported; the forecaster's own chance of this, stated with the estimate: 75%; the middle value is on the limit's open side.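

In this assay compound 4 gives only a limit, > 20000 nM. For the compounds shown here, no new step from compound 1, compound 2 or compound 3 to compound 4 can be read, because the comparison runs into a limit: the limit of > 20000 nM in this assay, at which 3 of the 4 values shown sit. On these data alone, how far butylamino and isobutylamino differ in this read-out stays open.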